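Glycoside-linked sulfonyl valines against a matrix metalloproteinase

The compounds below may be only part of what the source reports. "The series", "measured", "known", "first", "only" and "open" are said of these compounds alone.

Measured compounds:
compound 1 `CO[C@@H]1O[C@H](CNC(=S)NCCN([C@@H](C(=O)O)C(C)C)S(=O)(=O)c2ccc(-c3ccccc3)cc2)[C@@H](O)[C@H](O)[C@H]1O`: 520 nM
compound 2 `CC(=O)N[C@@H]1[C@@H](O)[C@H](O)[C@@H](CO)O[C@H]1N([C@@H](C(=O)O)C(C)C)S(=O)(=O)c1ccc(-c2ccccc2)cc1`: "not determined" (no result reported)

In an assay on isolated protein for inhibition of matrix metalloproteinase-9 (Homo sapiens), read by fluorescence, with stated times of 3 h, 10 s and 15 min (on this read-out lower numbers stand for stronger inhibition and higher numbers for weaker inhibition), compound 1 gives 520 nM. For the measured compounds named here, compound 2 carries the sugar directly on the sulfonamide nitrogen rather than through the thiourea-linked chain of compound 1, and in this assay compound 2 returns "not determined" (no result reported), so no single number places it on this scale, and no step between the two measured compounds can be read.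

Compound 3 `CC(C)[C@H](C(=O)O)N([C@@H]1O[C@H](CO)[C@@H](O)[C@H](O)[C@H]1O)S(=O)(=O)c1ccc(-c2ccccc2)cc1` is the next member. It differs from compound 2 by hydroxy in place of acetamido on a saturated ring carbon. With compound 2 lacking a number, the size and direction of this step cannot be anchored; compound 1 remains the only reference point. The expectation for compound 3 is therefore a moderate inhibitory concentration broadly like that of compound 1, estimated at 1000 nM, within 200 nM to 5000 nM.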

Compound 3, half-maximal inhibitory concentration: > 50000 nM
Compound 3 gave a limit, no number (the forecaster's own chance of this, stated with the estimate: 20%); middle value at least 50-fold (1.69 log units) away from the limit.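

Compound 3 gives > 50000 nM, which is a limit and not a number. For the compounds shown here, with no result reported for compound 2, no step between compound 2 and compound 3 can be read. The compounds shown leave open what swapping acetamido for hydroxy on the saturated ring carbon does to inhibition.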